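The source may hold more compounds than are shown below. What is called first, only, known or untested is meant among the compounds shown, and "the series" means these compounds.

Working notes on the series.

Compound 1 `Cc1cnc(Nc2ccc(Cl)cc2)nc1Nc1nc2ccccc2s1` is the starting point of this step. In a functional assay on HeLa cells (Homo sapiens) for antiproliferative activity, read by MTT assay, with a stated time of 48 h (a higher number here means a weaker inhibitor, a lower number a stronger inhibitor), compound 1 gives > 50000 nM, which is a limit of the assay and not a number. The two other measured members are compound 2 `CS(=O)(=O)c1ccc(Nc2nccc(Nc3nc4ccc(F)cc4s3)n2)cc1` and compound 3 `CS(=O)(=O)c1ccc(Nc2ncc(F)c(Nc3nc4ccc(F)cc4s3)n2)cc1`. In this assay compound 2 gives 560 nM. In this assay compound 3 gives > 50000 nM, again a limit of the assay. Within the data shown here, the one measured step, an at least 89-fold higher number from compound 2 to compound 3 (1.95 log units; beyond the scatter), concerns fluoro in place of hydrogen on an aromatic carbon of the shared core, and it is large. Where compound 1 stands can only be stated as the limit of > 50000 nM in this assay, at which 2 of the 3 values shown sit.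

Compound 4 `Cc1cnc(Nc2cccc(F)c2)nc1Nc1nc2ccccc2s1` differs from compound 1 by 3-fluorophenyl in place of 4-chlorophenyl on a nitrogen on an aromatic ring. Among the measured compounds shown here, no measured step touches this position; the step of an at least 89-fold higher number from compound 2 to compound 3 (1.95 log units; beyond the scatter) sits elsewhere on the core and so offers no direct guide, and the pair compound 1 and compound 3 shows only that both sit at the limit. With compound 1 at a limit in this assay, no step beyond the scatter can be read in either direction, and the expectation is that compound 4 is estimated to remain at or near that limit, i.e. a step that the limit leaves unreadable from compound 1 to compound 4. Compound 4 is therefore expected at 60000 nM, within 15000 nM to 200000 nM.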

Compound 4, half-maximal inhibitory concentration: 16300 nM
For compound 4 the middle estimate is 3.7-fold (0.57 log units) above the measured one; the range from low to high includes it.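

In this assay the change from 4-chlorophenyl to 3-fluorophenyl on a nitrogen on an aromatic ring gives an at least 3.0-fold lower number from compound 1 to compound 4 (0.48 log units; beyond the scatter), so this position can bring the core of compound 1 to a readable value. The earlier step concerned a different place on the core and ran towards a higher number, so this is the first change shown to run towards a lower number, and the first that starts from a limit of the assay and ends on a measured value. The step can be read only as a bound and not as a size, because compound 1 stands at a limit of the assay: the limit of > 50000 nM in this assay, at which 2 of the 4 values shown sit.

The change replaces chlorine with fluorine and alters the substituted ring place in one move, so the compounds shown cannot assign the step to either part alone. They also leave open whether this position accepts a different kind of group on the phenyl ring, such as an amine, a carboxylic acid or a methylsulfonyl group, on the core of compound 1.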